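The source may report more compounds than this note shows. Statements on the series, on what has been measured and on what is new or still open speak of the compounds shown alone.

Among the compounds with values here, compound 2 `Cc1ccc(-c2nc(=O)o[nH]2)c(-c2ccc([C@@H](C)N(CC3CC3)c3nc(C(=O)NS(=O)(=O)C4CC4)c(C(C)C)s3)cc2)c1` gives 5.2 h in an ADME assay on the whole organism (Macaca fascicularis) (a lower number here means that the compound disappears faster, a higher number that the compound lasts longer), the higher of the two numbers so far; compound 1 `CCc1sc(N(CC2CC2)[C@H](C)c2ccc(-c3cc(C)ccc3-c3nc(=O)o[nH]3)cc2)nc1C(=O)NS(=O)(=O)C1CC1` gives 2.9 h, and the step of a 1.8-fold higher number from compound 1 to compound 2 (0.25 log units; within the scatter) stays within the scatter. Compound 3 `Cc1ccc(-c2nc(=O)o[nH]2)c(-c2ccc([C@@H](C)N(CC3CC3)c3nc(C(=O)NS(=O)(=O)C4CC4)c(CC(C)C)s3)cc2)c1` carries isobutyl in place of isopropyl on an aromatic carbon. Within the data shown here, the only measured step, a 1.8-fold higher number from compound 1 to compound 2 (0.25 log units; within the scatter), also grows the chain on that same aromatic carbon and moved the number little, so for compound 3 a step of a 1.1-fold higher number from compound 2 to compound 3 (0.02 log units; within the scatter) within the scatter is expected, with no clear direction. Compound 3 is estimated at 5.5 h, with a range of 2.6 h to 11.5 h.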

Compound 3, mean residence time: 4.9 h
The estimate for compound 3 lay 1.1-fold (0.05 log units) above the measured number; low and high end bracket the measured number.
By their numbers in this assay, from the lowest: compounds 1, 3 and 2 (each within the scatter of the next).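

At this aromatic carbon next to the ring sulfur, isobutyl in place of isopropyl gives a 1.1-fold lower number from compound 2 to compound 3 (0.03 log units; within the scatter) in this assay, so the added carbon shows no readable effect on residence time. The wider change in the chain gives a 1.7-fold higher number from compound 1 to compound 3 (0.23 log units; within the scatter), so all three chains at this position now lie within the scatter of one another. No other data on these compounds bear on this result.

Open, as far as these compounds go, is whether a different kind of group here, such as an amine, a carboxylic acid or a phenyl ring, would move the residence time beyond the scatter.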